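This account rests on a few compounds, and the source may have more. Where it says the series, first, only, none or still open, it means among the compounds named here.

Compound 3 `CN1CCN(c2ccc(Nc3nc(-c4cccc(NC(=O)c5ccco5)c4)sc3C(N)=O)cc2)CC1` gives 96.7% in a functional assay on Ramos cells (Homo sapiens) for antiproliferative activity, read by CCK-8 assay, with a stated time of 72 h, tested at 40 uM (on this read-out higher numbers stand for more inhibition at the one concentration tested (going by the name of the read-out) and lower numbers for less inhibition), the highest of the three numbers recorded, though compound 2 `CN1CCN(c2ccc(Nc3nc(-c4cccc(NC(=O)c5ccccc5F)c4)sc3C(N)=O)cc2)CC1` with 95.5% sits within the scatter of it; compound 1 `CN1CCN(c2ccc(Nc3nc(-c4cccc(NC(=O)c5ccc(C(C)(C)C)cc5)c4)sc3C(N)=O)cc2)CC1` with 80.1% lies furthest away. The change to compound 4 `CN1CCN(c2ccc(Nc3nc(-c4cccc(NC(=O)[C@H]5CC[C@H](C)CC5)c4)sc3C(N)=O)cc2)CC1` is 4-methylcyclohexyl in place of furan-2-yl on a carbonyl carbon. For the measured compounds named here, three measured steps touch the same carbonyl carbon: a number 15.4 percentage points higher from compound 1 to compound 2 (beyond the scatter), a number 16.6 percentage points higher from compound 1 to compound 3 (beyond the scatter) and a number 1.2 percentage points higher from compound 2 to compound 3 (within the scatter). The two modest rises both began from compound 1, which carries 4-(tert-butyl)phenyl, while the exchange of 2-fluorophenyl for furan-2-yl changed nothing beyond the scatter. None of these steps places a six-membered non-aromatic ring of carbon only on that carbon, so the data give no direct guide; only compound 1 shows that a group other than furan-2-yl here can lower the number. On that basis a modest downward step of a number 11.7 percentage points lower from compound 3 to compound 4 (beyond the scatter) is expected, with no change beyond the scatter also possible. Compound 4 is therefore estimated at 85%, within a range from 68% to 97%.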

Compound 4, a percentage reported as inhibition, at one concentration (the size of the read-out at that concentration, not a potency): 55.1%
Compound 4: the middle estimate sits 29.9 percentage points above what was measured; measured number below the stated range.
By their numbers in this assay, from the lowest: compound 4; then compound 1; then compounds 2 and 3 (each within the scatter of the next).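

In this assay, the carbonyl carbon turns out to allow a large fall: 4-methylcyclohexyl in place of furan-2-yl gives a number 41.6 percentage points lower from compound 3 to compound 4 (beyond the scatter), and in place of 2-fluorophenyl it gives a number 40.4 percentage points lower from compound 2 to compound 4 (beyond the scatter). The same group also falls short of the earlier low point, with a number 25 percentage points lower from compound 1 to compound 4 (beyond the scatter), so the only compound with a six-membered non-aromatic ring of carbon only on this carbon stands lowest of the four, and no compound shown goes against this single example. No evidence is available on what lies behind these falls.

On these data alone, how a plain cyclohexyl or a piperidin-4-yl, which brings an amine into the ring, would read on this carbonyl carbon stays open. As far as these compounds go, whether the methyl on the ring contributes to the fall also stays open.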